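Benzyl Ether in Place of Hydroxy on Compound 2

The compounds below may be only part of what the source reports. "The series", "measured", "known", "first", "only" and "open" are said of these compounds alone.

Measured compounds:
Compound 1, `CCCSc1nc(N)cc(OCc2ccccc2)n1`, in a functional assay on HepG2 cells (Homo sapiens) for antiproliferative activity, read by MTT assay, with a stated time of 72 h (a higher number here means a weaker inhibitor of growth, a lower number a stronger inhibitor of growth), gives 87100 nM.
Compound 2, `Cc1cc(O)n2cc(-c3ccc([N+](=O)[O-])cc3)nc2n1`, is recorded in this assay only as a limit, > 100000 nM.

Compound 2 therefore has no number of its own in this assay; it stands at the edge of what the assay reports, as the record the limit of > 100000 nM in this assay, at which 1 of the 2 values shown sits, shows. Compound 1, which already carries a benzyloxy group on its core, sits just inside the range with 87100 nM, a weak inhibitor of growth.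

Compound 3, `Cc1cc(OCc2ccccc2)n2cc(-c3ccc([N+](=O)[O-])cc3)nc2n1`, is the next member. It differs from compound 2 in one place: benzyl in place of hydrogen on an oxygen on an aromatic ring. Going by the values given here, no measured step of this kind exists here, so the expectation rests only on the two compounds above. Since compound 1 with its benzyloxy group gives only 87100 nM, a step from compound 2 to compound 3 is expected to be small, no further than the scatter, and compound 3 may well remain at the edge of what the assay reports.

The expected step is an at least 1.1-fold lower number from compound 2 to compound 3 (0.04 log units; that floor lies within the scatter). Compound 3 is estimated at 90000 nM, within 30000 nM to 200000 nM.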

Compound 3, concentration for 50% growth inhibition: > 100000 nM
Compound 3: a limit, no number; the forecaster's own chance of this, stated with the estimate: 45%; at least 1.1-fold (0.04 log units) between middle value and limit.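

Compound 3 is recorded in this assay only as a limit, > 100000 nM. Compound 2 is also recorded only as a limit, so no step can be read between compound 2 and compound 3: the limit of > 100000 nM in this assay, at which 2 of the 3 values shown sit.

The compounds shown leave open whether benzyloxy in place of hydroxy changes growth inhibition at all.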